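This account rests on a few compounds, and the source may have more. Where it says the series, first, only, none or still open, it means among the compounds named here.

Compounds measured so far in a functional assay on PC-12 cells (Rattus norvegicus) for cytotoxicity, read by MTT assay, with stated times of 3 h and 2 h, tested at 50 uM; on this read-out lower numbers stand for a weaker effect and higher numbers for a stronger effect at the one concentration tested:
- compound 1 `O=C(CCCCC1CCSS1)NCc1cn(CCCCOc2ccc3cc(-c4ccccc4)c(=O)oc3c2)nn1`: 20.5%
- compound 2 `COc1ccc(-c2cc3ccc(OCCCCn4cc(CNC(=O)CCCCC5CCSS5)nn4)cc3oc2=O)cc1`: 55.3%

For the measured compounds named here, compound 2 stands highest of the two numbers in this assay; its only neighbour is compound 1, and the one measured step between them, a number 34.8 percentage points higher from compound 1 to compound 2 (beyond the scatter), lies beyond the scatter and is large. Compound 3 `O=C(CCCCC1CCSS1)NCc1cn(CCCCOc2ccc3cc(-c4ccc(Br)cc4)c(=O)oc3c2)nn1` has not yet been measured. It differs from compound 2 by bromo in place of methoxy on an aromatic carbon.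

Going by the values given here, the only step that bears on this change is the one from compound 1 to compound 2, which shows that what sits at this position on the ring can shift the read-out strongly. Among the compounds with values here, no measured pair shows bromo against methoxy, so the direction cannot be taken from a like-for-like step. Since both compound 1 and compound 2 together span a wide range at this position, compound 3 is expected to fall between them rather than outside, with the step of a number 15.3 percentage points lower from compound 2 to compound 3 (beyond the scatter) expected to be a moderate drop. Compound 3 is therefore estimated at 40%, within 15% to 65%.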

Compound 3, a percentage reported as activity, at one concentration (the size of the read-out at that concentration, not a potency): 47.6%
For compound 3 the middle estimate is 7.6 percentage points below the measured one; low and high end bracket the measured number.
By their numbers in this assay, from the lowest: compound 1; then compounds 3 and 2 (each within the scatter of the next).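

In this assay, bromo in place of methoxy on this aromatic carbon gives a number 7.7 percentage points lower from compound 2 to compound 3 (within the scatter), so the read-out does not separate the two groups, although methoxy has 2 heavy atoms and 1 hydrogen-bond acceptor while bromo has 1 heavy atom and 0 hydrogen-bond acceptors. Bromo in place of hydrogen at the same carbon gives a number 27.1 percentage points higher from compound 1 to compound 3 (beyond the scatter), which provides a second comparison with the unsubstituted compound 1. The earlier step could have been read as specific to methoxy, but two different groups at this carbon now each stand beyond the scatter above hydrogen, and none of the three compounds goes against this. No measurement shown here accounts for the shared effect of these two groups.

The compounds shown leave open whether the pattern extends to other groups on this carbon, such as an amine, a carboxylic acid or a longer chain. They also leave open whether compound 2 and compound 3 would still match at other concentrations, since a reading at one concentration is not a potency.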